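The source may report more compounds than this note shows. Statements on the series, on what has been measured and on what is new or still open speak of the compounds shown alone.

In a physicochemical assay for lipophilicity, read by HPLC, measured as octanol-water partition, at pH 7.4 (a lower number here means a more polar compound, a higher number a more lipophilic compound), compound 1 (`NC(=O)[C@@H](CCC(F)(F)F)N(CC1CCCC1)S(=O)(=O)c1ccc(Cl)cc1`) stands highest of the three measured compounds at 5.15 against compound 2 (`NC(=O)[C@@H](CCC(F)(F)F)N(C[C@H]1CCCOC1)S(=O)(=O)c1ccc(Cl)cc1`) at 3.6 and compound 3 (`NC(=O)[C@@H](CCC(F)(F)F)N(CC1CCOCC1)S(=O)(=O)c1ccc(Cl)cc1`) at 3.5 on the same scale. The change to compound 4 (`NC(=O)[C@@H](CCC(F)(F)F)N(C[C@@H]1COCCO1)S(=O)(=O)c1ccc(Cl)cc1`), not yet measured, puts 1,4-dioxan-2-yl in place of cyclopentyl on a saturated chain carbon bound to a sulfonamide nitrogen. For the measured compounds named here, two measured steps bear on it: a number 1.55 log units lower from compound 1 to compound 2 (beyond the scatter) and a number 1.65 log units lower from compound 1 to compound 3 (beyond the scatter) are both large, while a number 0.10 log units lower from compound 2 to compound 3 (within the scatter) stays within the scatter. Neither large step involves 1,4-dioxan-2-yl, so the size is extrapolated. With compound 3 at 3.5 as the nearest guide, a further fall is expected. The expected step (a number 2.25 log units lower from compound 1 to compound 4 (beyond the scatter)) is large and downward in this assay as a working estimate. For compound 4 the estimated value is 2.9 (expected range 2.4 to 3.4).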

Compound 4, distribution coefficient: 2.75
Compound 4: middle estimate off by 0.15 log units, on the high side, within the range that was stated.
By their numbers in this assay, from the lowest: compound 4; then compounds 3 and 2 (each within the scatter of the next); then compound 1.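

In this assay, 1,4-dioxan-2-yl gives the largest fall yet seen at this position (a number 2.40 log units lower from compound 1 to compound 4 (beyond the scatter)). It also stands apart from both oxane-bearing compounds (a number 0.75 log units lower from compound 3 to compound 4 (beyond the scatter); a number 0.85 log units lower from compound 2 to compound 4 (beyond the scatter)), so the choice among these oxygen-containing rings can move the number beyond the scatter, although oxan-3-yl and oxan-4-yl could not be separated. No measurement on hand explains this order.

Open, as far as these compounds go, is whether the opposite configuration at the defined stereocentre of 1,4-dioxan-2-yl reads the same in this assay, and where an amine or a carboxylic acid in place of cyclopentyl would stand.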